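A few compounds are considered here, and "the series" means these few. Any claim that something is new, unique, unknown or untested is made for them only; others in the source may bear on it.

Of the compounds shown here, two have been measured so far in an assay (Equus caballus) for inhibition of Thromboxane-A synthase (Homo sapiens), using microsomes; on this read-out higher numbers stand for weaker inhibition and lower numbers for stronger inhibition. Compound 1, with the structure `NC(=O)CCCC/C=C(\c1ccccc1)c1cccnc1`, gives 400 nM. Compound 2, with the structure `O=C(O)CCCC/C=C(/c1cccnc1)c1cccs1`, gives 54 nM. Of these two numbers, compound 1 holds the higher one, and the gap down to compound 2 lies beyond the usual scatter, so compound 1 is the weaker inhibitor of the pair. The two structures differ in more than one place, so the gap cannot be tied to a single change.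

Compound 3, with the structure `CC(C)(CCCC/C=C(\c1ccccc1)c1cccnc1)C(=O)O`, has not yet been measured in this assay. It differs from compound 1 in one place: 1-carboxy-1-methylethyl in place of carbamoyl on a saturated chain carbon, four bonds along the chain from a double-bonded chain carbon. The carbamoyl group of compound 1 thus gives way to a 1-carboxy-1-methylethyl group on the saturated chain carbon.

Among the measured compounds shown here, the step from compound 1 to compound 3 is expected to move toward stronger inhibition, by a 5.7-fold lower number from compound 1 to compound 3 (0.76 log units; beyond the scatter), since the only compound that carries a carboxylic acid, compound 2, gives 54 nM. Compound 3 is therefore estimated at 70 nM, with a likely range from 15 nM to 300 nM.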

Compound 3, half-maximal inhibitory concentration: 45 nM
Estimate against measurement, compound 3: 1.6-fold (0.19 log units) above; low and high end bracket the measured number.
By their numbers in this assay, from the lowest: compounds 3 and 2 (each within the scatter of the next); then compound 1.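

In this assay, the earlier pair could not tie a gap to any one group, but here a single change on an otherwise shared core gives an 8.9-fold lower number from compound 1 to compound 3 (0.95 log units; beyond the scatter). This links the group on the saturated chain carbon, four bonds along the chain from a double-bonded chain carbon, to a clear shift toward stronger inhibition, so the end of this chain matters for the read-out. The entering 1-carboxy-1-methylethyl group differs from carbamoyl in both its acid function and its extra carbons, and no information here explains the gain or divides it between those two features.

On these data alone, it remains open whether a plain carboxylic acid on the same chain, without the branching methyl groups, would give a similar number, and so whether the branching contributes anything at all. As far as these compounds go, it is also open how a methyl ester or a tetrazole would behave in this place, and whether a shorter or longer chain would keep the stronger inhibition seen with compound 3.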